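The source may hold more compounds than are shown below. What is called first, only, known or untested is meant among the compounds shown, and "the series" means these compounds.

The compounds here share one core and differ in the group on its nitrogen. In a functional assay on COLO 205 cells (Homo sapiens) for cytotoxicity, read by MTT assay, with a stated time of 48 h (on this read-out higher numbers stand for weaker inhibition and lower numbers for stronger inhibition), compound 1 `Fc1cccc(-c2nc(Nc3ccc(Cl)cc3)c3cc(F)ccc3n2)c1`, with a 4-chlorophenyl group, gives 32600 nM. Compound 2 `Nc1ccc(Nc2nc(-c3cccc(F)c3)nc3ccc(F)cc23)cc1` gives > 50000 nM, which is a limit of the assay and not a number. Compound 3 `Nc1ccccc1Nc1nc(-c2cccc(F)c2)nc2ccc(F)cc12` gives > 50000 nM, which is also a limit. Compound 3 therefore has no number of its own and stands at the limit of > 50000 nM in this assay, at which 2 of the 3 values shown sit.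

The next compound, compound 4 `Cc1ccccc1Nc1nc(-c2cccc(F)c2)nc2ccc(F)cc12`, has methyl in place of amino on an aromatic carbon, ortho to a large group: methyl in place of amino on an aromatic carbon. Within the data shown here, three measured steps bear on this change. The first is an at least 1.5-fold higher number from compound 1 to compound 2 (0.18 log units; that floor lies within the scatter), and the second is an at least 1.5-fold higher number from compound 1 to compound 3 (0.18 log units; that floor lies within the scatter). Both are only floors, so neither shows a real change. The third is a step that the two limits leave unreadable from compound 2 to compound 3.

Among the measured compounds shown here, the one firm number belongs to compound 1 at 32600 nM, the only compound here without an amino group. Compound 4 also lacks that group, so a modest move toward a lower number is expected, though a size cannot be read from limits. The expected change is an at least 1.4-fold lower number from compound 3 to compound 4 (0.15 log units; that floor lies within the scatter). Another limit reading would be no surprise. For compound 4 the estimated value is 35000 nM, with an expected range from 15000 nM to 70000 nM.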

Compound 4, half-maximal inhibitory concentration: > 50000 nM
Compound 4 was reported as a limit; the forecaster's own chance of this, stated with the estimate: 35%; middle value at least 1.4-fold (0.15 log units) away from the limit.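

In this assay compound 4 gives > 50000 nM, which is a limit of the assay and not a number, so methyl in place of amino at this position does not produce a readable value. Among these compounds, the steps that join the compounds sitting at the limit cannot be read, and the only readable step, an at least 1.5-fold higher number from compound 1 to compound 4 (0.18 log units; that floor lies within the scatter), shows no real change. What is new is that lacking an amino group no longer sets compound 1 apart, since compound 4 lacks one too and still stands with the others at the limit: the limit of > 50000 nM in this assay, at which 3 of the 4 values shown sit.

Left open is whether the one firm number, the 32600 nM of compound 1, goes with the chloro group itself or with its place on the ring, as the other compounds shown carry no chloro. A 2-chlorophenyl or a 4-methylphenyl group on the same nitrogen would speak to that question, and a 2-methoxyphenyl group would test whether any group at this position gives a number at all.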